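From Chloro to Bromo: Expecting No Real Change

The compounds below may be only part of what the source reports. "The series", "measured", "known", "first", "only" and "open" are said of these compounds alone.

Of the compounds shown here, three have been tested in a functional assay on the whole organism (plasma, strain Wistar) with Rattus norvegicus as the target, with a stated time of 15 days, at a dose of 100 mg/kg by the oral route; on this read-out higher numbers stand for a stronger effect at the one dose given and lower numbers for a weaker effect. Compound 1 `Cc1ccc(-c2nnc(SCCOc3ccc(/C=C4\SC(=O)NC4=O)cc3)[nH]2)cc1` gives 29.7%, compound 2 `O=C1NC(=O)/C(=C/c2ccc(OCCSc3nnc(-c4ccccc4[N+](=O)[O-])[nH]3)cc2)S1` gives 26.8%, and compound 3 `O=C1NC(=O)/C(=C/c2ccc(OCCSc3nnc(-c4ccc(Cl)cc4)[nH]3)cc2)S1` gives 28.9%. Compound 3 sits within the scatter of both others, with a number 0.8 percentage points lower from compound 1 to compound 3 (within the scatter) and a number 2.1 percentage points higher from compound 2 to compound 3 (within the scatter), and the remaining step, a number 2.9 percentage points lower from compound 1 to compound 2 (within the scatter), is also within the scatter. Compound 4 `O=C1NC(=O)/C(=C/c2ccc(OCCSc3nnc(-c4ccc(Br)cc4)[nH]3)cc2)S1` differs from compound 3 by bromo in place of chloro on an aromatic carbon. Going by the values given here, the one measured step that also exchanges the group on that aromatic carbon, a number 0.8 percentage points lower from compound 1 to compound 3 (within the scatter), did not move the read-out beyond the scatter, so no shift beyond the scatter is expected here either. Compound 4 is therefore expected to give about 29%, with a range from 21% to 37%. This corresponds to an expected step of a number 0.1 percentage points higher from compound 3 to compound 4 (within the scatter).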

Compound 4, a percentage reported as activity, at one dose (the size of the read-out at that dose, not a potency): 28.5%
Estimate against measurement, compound 4: 0.5 percentage points above; the measured number falls inside the stated range.
By their numbers in this assay, from the lowest: compounds 2, 4, 3 and 1 (each within the scatter of the next).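

Exchanging chloro for bromo on this aromatic carbon, para to a large group, gives (a number 0.4 percentage points lower from compound 3 to compound 4 (within the scatter)) in this assay, so this position now carries a second halogen without a shift beyond the scatter. The 4-bromophenyl compound also stays close to the two other groups, with (a number 1.7 percentage points higher from compound 2 to compound 4 (within the scatter)) against 2-nitrophenyl and (a number 1.2 percentage points lower from compound 1 to compound 4 (within the scatter)) against methyl. No measurement here offers a reason for these small steps.

As far as these compounds go, whether an amine or a carboxylic acid at this position would move the read-out beyond the scatter remains open. These numbers also describe the size of the effect at the one dose given and nothing at any other dose.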